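This account rests on a few compounds, and the source may have more. Where it says the series, first, only, none or still open, it means among the compounds named here.

Two closely related compounds have numbers in a functional assay on HCT-116 cells (Homo sapiens) for antiproliferative activity; on this read-out lower numbers stand for stronger inhibition and higher numbers for weaker inhibition. There, compound 1 (`Cc1c2c(n3c1CCCN[C@@H](C)[C@H](C)Nc1cc-3ccc1C(N)=O)CC(C)(C)CC2=O`) gives 29 nM, and compound 2 (`CC(=O)N1CCc2c(C)c3c(n2-c2ccc(C(N)=O)c(c2)N[C@@H](C)[C@H](C)C1)CC(C)(C)CC3=O`), which carries an acetyl group on an amide-type nitrogen in a ring, gives 24 nM. These two values lie within the usual scatter of each other, so compound 2 stands level with compound 1 and neither can be ranked above the other.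

Compound 3 (`Cc1c2c(n3c1CCN(C(=O)[C@@H](N)C(C)C)C[C@@H](C)[C@H](C)Nc1cc-3ccc1C(N)=O)CC(C)(C)CC2=O`) has not yet been measured in this assay. It departs from compound 2 in one place: 1-amino-2-methylpropyl in place of methyl on a carbonyl carbon. This puts 1-amino-2-methylpropyl in place of methyl on a carbonyl carbon, turning acetyl into (1-amino-2-methylpropyl)carbonyl.

Among the compounds with values here, no measured pair isolates this change, so the expectation rests on little evidence. The structures of the two measured compounds differ, yet compound 1 at 29 nM and compound 2 at 24 nM remain within the scatter, so only a modest rise in the number, towards weaker inhibition, is expected. The expected step is a 1.5-fold higher number from compound 2 to compound 3 (0.16 log units; within the scatter), which may not clear the scatter. For compound 3 the estimated value is 35 nM, with an expected range of 12 nM to 100 nM.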

Compound 3, half-maximal inhibitory concentration: 30 nM
The estimate for compound 3 lay 1.2-fold (0.07 log units) above the measured number; the range from low to high includes it.
By their numbers in this assay, from the lowest: compounds 2, 1 and 3 (each within the scatter of the next).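

In this assay, 1-amino-2-methylpropyl in place of methyl on a carbonyl carbon whose other neighbour is an amide-type nitrogen in a ring gives a 1.3-fold higher number from compound 2 to compound 3 (0.10 log units; within the scatter), so this read-out does not separate the two compounds. Within the data shown here, this is the first step that isolates a single change at this position, and it shows that a group of five heavy atoms, with an amino group and a defined stereocentre, can stand where one carbon stood without the number leaving the scatter of compound 2. Nothing measured here accounts for this result, and the step describes only what the read-out shows for this one pair.

The compounds shown leave open which part of the new group matters, as no counterpart here has a plain isobutyl group without the amino group or the opposite configuration at the defined stereocentre. They also leave open whether the same holds for other groups on this carbonyl carbon, such as a carboxylic acid, a dimethylamino group or a longer chain, since one step cannot show how far this extends.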